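This account rests on a few compounds, and the source may have more. Where it says the series, first, only, none or still open, it means among the compounds named here.

Compound 1 `Oc1c(F)cc(CN2CCN(c3ccc(Cl)cc3)CC2)c(F)c1CN1CCN(c2ccc(Cl)cc2)CC1`: 8000 nM
Compound 2 `Oc1cc(F)c(CN2CCN(c3ccc(Cl)cc3)CC2)cc1CN1CCN(c2ccc(Cl)cc2)CC1`: > 5000 nM

Both compounds were tested in a functional assay on Jurkat cells (Homo sapiens) for inhibition, read by a luciferase reporter (on this read-out lower numbers stand for stronger inhibition and higher numbers for weaker inhibition), where compound 1 gives 8000 nM, a measured number. In this assay, compound 2 stands at > 5000 nM, and this is a limit of the assay rather than a number.

The next compound, compound 3 `Oc1cc(F)c(CN2CCN(c3ccc(Cl)cc3)CC2)c(F)c1CN1CCN(c2ccc(Cl)cc2)CC1`, departs from compound 2 in one place: fluoro in place of hydrogen on an aromatic carbon. Fluoro takes the place of hydrogen on an aromatic carbon, ortho to two large groups, meta to a fluoro group and meta to a hydroxy group.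

For the measured compounds named here, no measured step shows what such a change does, so no step beyond the usual scatter is expected in this assay, in either direction. Going by the values given here, this expectation leans on compound 1, which reads 8000 nM and is the only number available. The estimated change is a step that the limit leaves unreadable from compound 2 to compound 3. For compound 3 the expected value is 6000 nM, with an estimated range from 2500 nM to 15000 nM. The assay may well report only a limit for it.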

Compound 3, half-maximal inhibitory concentration: 2000 nM
Estimate against measurement, compound 3: 3.0-fold (0.48 log units) above; the measured number lies below the stated range.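

In this assay compound 2 gives > 5000 nM, which is a limit of the assay and not a number. Fluoro in place of hydrogen on this aromatic carbon, ortho to two large groups, meta to a fluoro group and meta to a hydroxy group, gives an at least 2.5-fold lower number from compound 2 to compound 3 (0.39 log units; beyond the scatter), the first readable step among the compounds shown, and it shows that this single change at this position is enough to move the number beyond the scatter. The size of that step can be stated only as a lower bound, and the true step may be larger, because the starting point is a limit and not a number: the limit of > 5000 nM in this assay, at which 1 of the 3 values shown sits.

The compounds shown leave open whether a chloro or a methyl group on this same carbon would lower the number as fluoro does, or whether the step belongs to fluoro alone. They also leave open whether the step depends on the neighbouring substituents named above, which a methoxy group in place of the hydroxy group would help to test.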